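The compounds below may be only part of what the source reports. "The series", "measured", "known", "first", "only" and "open" are said of these compounds alone.

Among the compounds with values here, compound 1 `CC(c1cc2cccnc2cc1F)n1cnc2ncc(-c3cnn(C)c3)nc21` is the only member of this small set with a number attached: in a functional assay on NCI-H1993 cells (Homo sapiens) for inhibition, read by CCK-8 assay, with a stated time of 72 h (on this read-out higher numbers stand for weaker inhibition and lower numbers for stronger inhibition), compound 1 gives 31.3 nM. Compound 2 `Cc1cc2ncccc2cc1C(C)n1cnc2ncc(-c3cnn(C)c3)nc21` belongs to the same series, but in this assay compound 2 is recorded as "not determined" (no result reported), so it offers no second point of reference. Compound 3 `CC(c1cc2cccnc2cc1F)n1cnc2ncc(-c3cnc4ccccc4c3)nc21` is the untested member. It differs from compound 1 in one place, where (quinolin-3-yl in place of 1-methyl-1H-pyrazol-4-yl on an aromatic carbon). Within the data shown here, with only one number known, no step between measured compounds can be drawn, and the size of this change must be expected rather than read off. The author expects the step from compound 1 to compound 3 to be a modest gain, a 2.1-fold lower number from compound 1 to compound 3 (0.32 log units; beyond the scatter), though one that may not exceed the usual scatter. For compound 3 the estimated value in this assay is 15 nM, with a likely range from 4 nM to 60 nM.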

Compound 3, half-maximal inhibitory concentration: 109 nM
The estimate for compound 3 lay 7.3-fold (0.86 log units) below the measured number, outside the stated range (above it).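

In this assay, the step from 1-methyl-1H-pyrazol-4-yl to quinolin-3-yl on this aromatic carbon is a 3.5-fold higher number from compound 1 to compound 3 (0.54 log units; beyond the scatter), so this position does respond to the group it carries, and here the larger group, with 10 heavy atoms against 6, goes with weaker inhibition. The change alters ring size, ring count, heavy atoms and hydrogen-bond acceptors all at once, so this single step cannot separate their contributions. No measurement at hand accounts for the step.

Any step involving compound 2 cannot be read, so the effect of the other site remains unknown alongside this one. Also open, on these data alone, is whether a smaller group on this carbon, such as an amine, or a longer chain in place of the methyl on the pyrazole nitrogen, would match or improve on compound 1.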